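The compounds below may be only part of what the source reports. "The series", "measured", "known", "first", "only" and "open" are said of these compounds alone.

In a series of styryl-quinoline compounds sharing one core, three members have been tested in a functional assay on HeLa cells (Homo sapiens) for antiproliferative activity, read by sulforhodamine B assay, with a stated time of 72 h; a higher number here means a weaker inhibitor, a lower number a stronger inhibitor. Compound 1 `FC(F)(F)c1ccc(/C=C\c2cc3ccccc3nc2Cl)cc1` gives 4220 nM in this assay. Compound 2 `COc1ccc2nc(Cl)c(/C=C\c3ccc(C(F)(F)F)cc3)cc2c1` gives 16200 nM. Compound 3 `COc1ccc2nc(Cl)c(/C=C\c3cc(C(F)(F)F)cc(C(F)(F)F)c3)cc2c1` gives 4140 nM, which places it within the scatter of compound 1, so no order between these two can be read; compound 2 stands well apart from both.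

Compound 1 differs from compound 2 in a single place: hydrogen in place of methoxy on an aromatic carbon. In this assay the step of a 3.8-fold lower number from compound 2 to compound 1 (0.58 log units; beyond the scatter) falls beyond the scatter and counts as a modest gain. How the core of compound 3 differs from that of compound 2 is not broken down here.

Compound 4 `FC(F)(F)c1cc(/C=C\c2cc3ccccc3nc2Cl)cc(C(F)(F)F)c1` has not yet been measured. It stands to compound 3 as compound 1 stands to compound 2: hydrogen in place of methoxy on an aromatic carbon. The place is described in the same words for both pairs, so this is the same change made a second time. Compound 4 is expected to move by a 3.2-fold lower number from compound 3 to compound 4 (0.50 log units; beyond the scatter), an estimate that rests on the earlier pair because a 3.8-fold lower number from compound 2 to compound 1 (0.58 log units; beyond the scatter) gave a modest, repeatable-looking gain when the methoxy was removed. On that basis compound 4 is estimated at 1300 nM, with a plausible range from 500 nM to 3500 nM.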

Compound 4, half-maximal inhibitory concentration: 6780 nM
Compound 4: middle estimate off by 5.2-fold (0.72 log units), on the low side; measured number above the stated range.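

In this assay, the step of a 1.6-fold higher number from compound 3 to compound 4 (0.21 log units; within the scatter) leaves compound 3 and compound 4 not separable, while the same exchange of methoxy for hydrogen on the other core gave a modest gain, so the gain did not carry over from one core to the other. The two cores answer differently to this one change, by more than the scatter of two such steps allows: the same change on two cores in this assay, a 3.8-fold lower number (0.58 log units; beyond the scatter) from compound 2 to compound 1 and a 1.6-fold higher number (0.21 log units; within the scatter) from compound 3 to compound 4, 6.3-fold (0.80 log units) apart, beyond the scatter of two such steps This shows that the gain seen with compound 1 cannot be assumed for a core with a different trifluoromethyl substitution, but it does not show what sets the two cores apart, and two pairs give no rule for any further core in the series.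

The compounds shown leave open how a different group in the place of the methoxy, such as a fluorine, an amine or a longer alkoxy chain, would read in this assay on either core. They also leave open whether replacing a trifluoromethyl group with a nitrile or a carboxylic acid would change how the two cores respond to losing the methoxy.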